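From Fluoro to Methoxy on the Phenyl Ring

The compounds below may be only part of what the source reports. "The series", "measured", "known", "first", "only" and "open" are said of these compounds alone.

Measured so far:
compound 1 `N#Cc1c(N2CCC(c3cccc(F)c3)CC2)ccn(CC2CC2)c1=O`: 268%
compound 2 `N#Cc1c(N2CCC(c3cccc(C(F)(F)F)c3)CC2)ccn(CC2CC2)c1=O`: 191%

In a functional assay on CHO cells for positive allosteric modulation of metabotropic glutamate receptor 2 (Homo sapiens), with a stated time of 30 min (on this read-out higher numbers stand for larger maximal responses and lower numbers for smaller maximal responses), compound 1 gives 268%, the higher of the two numbers measured. Among the measured compounds shown here, compound 2 gives 191%, and the only known step, a number 77 percentage points lower from compound 1 to compound 2 (beyond the scatter), came from changing the group on that phenyl ring. Compound 3 `COc1ccccc1C1CCN(c2ccn(CC3CC3)c(=O)c2C#N)CC1` differs from compound 1 by 2-methoxyphenyl in place of 3-fluorophenyl on a saturated ring carbon. For the measured compounds named here, no measured step tests a methoxy group or this ring substitution pattern, so the bearing of the known step is indirect: it only shows that altering the phenyl ring can lower the maximal response by a large amount. A moderate drop, a number 68 percentage points lower from compound 1 to compound 3 (beyond the scatter), is therefore expected, with wide uncertainty. Compound 3 is estimated at 200%, in a range from 120% to 280%.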

Compound 3, largest response reached (Emax), in percent of the reference or control that the assay uses: 265%
For compound 3 the middle estimate is 65 percentage points below the measured one, within the range that was stated.
By their numbers in this assay, from the lowest: compound 2; then compounds 3 and 1 (each within the scatter of the next).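

In this assay the swap of 3-fluorophenyl for 2-methoxyphenyl gives a number 3 percentage points lower from compound 1 to compound 3 (within the scatter) and the two groups cannot be told apart on this read-out. Among the compounds shown here, the earlier compounds showed only that a change on this phenyl ring can cost much of the maximal response, whereas this pair shows that a different group at a different ring place need not. Nothing measured here explains the match.

Methoxy and its ring place change together, so their separate contributions remain open. Also open, as far as these compounds go, is how an amine or a carboxylic acid on the phenyl ring would fare.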